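The compounds below may be only part of what the source reports. "The series", "measured", "known", "first", "only" and "open" are said of these compounds alone.

Compound 2 `COc1ccc2nc(Nc3nc(Nc4ccc(S(N)(=O)=O)cc4)ncc3F)sc2c1` sits at the upper edge of what has been seen so far. In a functional assay on MCF7 cells (Homo sapiens) for antiproliferative activity, read by MTT assay, with a stated time of 48 h (on this read-out lower numbers stand for stronger inhibition and higher numbers for weaker inhibition), compound 2 gives > 50000 nM, which is a limit of the assay and not a number. Compound 1 `COc1ccc2nc(Nc3nc(Nc4ccc(S(N)(=O)=O)cc4)ncc3C)sc2c1` carries a methyl where compound 2 carries a fluoro. In this assay compound 1 also gives > 50000 nM, again a limit. The step that the two limits leave unreadable from compound 1 to compound 2 is therefore unreadable, since both compounds sit at the limit of > 50000 nM in this assay, at which 2 of the 3 values shown sit. Going by the values given here, compound 3 `COc1ccc2nc(Nc3nc(Nc4ccc(S(C)(=O)=O)cc4)ncc3F)sc2c1` replaces the amino group on the sulfonyl sulfur with a methyl and gives 5850 nM in this assay, so the step of an at least 8.5-fold lower number from compound 2 to compound 3 (0.93 log units; beyond the scatter) is the only readable change in the set.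

Compound 4 `COc1ccc2nc(Nc3ccnc(Nc4ccc(S(N)(=O)=O)cc4)n3)sc2c1` differs from compound 2 by hydrogen in place of fluoro on an aromatic carbon. Among the compounds with values here, no measured step bears directly on this change: the swap from methyl to fluoro at the same carbon was left unreadable by the two limits, and the readable step from compound 2 to compound 3 concerns the sulfonyl group, not this ring carbon. With nothing pointing either way, the step of a number no higher from compound 2 to compound 4 (the limit leaves the size open) is expected to lie within the scatter, and compound 4 is estimated to give about 50000 nM in this assay, somewhere between 15000 nM and 150000 nM, most likely reported only as a limit.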

Compound 4, half-maximal inhibitory concentration: 11000 nM
Estimate against measurement, compound 4: 4.5-fold (0.66 log units) above, outside the stated range (below it).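

Hydrogen at this carbon of the six-membered aromatic ring with 2 nitrogen gives a readable change in this assay: an at least 4.5-fold lower number from compound 2 to compound 4 (0.65 log units; beyond the scatter), and an at least 4.5-fold lower number from compound 1 to compound 4 (0.65 log units; beyond the scatter). Each of these steps gives only a minimum size, because compound 1 and compound 2 both stop at a limit of the assay, not at a number: the limit of > 50000 nM in this assay, at which 2 of the 4 values shown sit. Going by these compounds alone, until now the only readable change lay on the sulfonyl sulfur, whereas this result shows that the ring carbon also matters, with hydrogen giving a lower number than either methyl or fluoro while the rest of the molecule stays the same.

Going by these compounds, it remains open whether hydrogen at this carbon would lower the number further when a methyl stands on the sulfonyl sulfur, as it does in compound 3, or whether the two changes would not add up at all. On these data alone, it is also open how a chloro group or a nitrile at this carbon would compare with hydrogen, and how large the true steps from methyl and fluoro are.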